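Removing One Hydroxy From the Thioether Chain of Compound 1

This account rests on a few compounds, and the source may have more. Where it says the series, first, only, none or still open, it means among the compounds named here.

Measured compounds:
Compound 1 `CC(C)c1n[nH]c2c(NCc3ccc(-c4ccccn4)cc3)nc(SCC(O)CO)nc12`: 21 nM
Compound 2 `CC(C)c1n[nH]c2c(NCc3ccc(-c4ccccn4)cc3)nc(SCC(O)CN3CCNCC3)nc12`: 332 nM

In a functional assay on HT cells (Homo sapiens) for antiproliferative activity, read by fluorescence, with a stated time of 72 h (on this read-out lower numbers stand for stronger inhibition of growth and higher numbers for weaker inhibition of growth), compound 1 gives 21 nM and stands lowest of the two numbers measured; compound 2 lies beyond the scatter from it, with a 16-fold higher number from compound 1 to compound 2 (1.20 log units; beyond the scatter). Compound 3 `CC(C)c1n[nH]c2c(NCc3ccc(-c4ccccn4)cc3)nc(SCCCO)nc12` differs from compound 1 by hydrogen in place of hydroxy on a saturated chain carbon bound to two saturated chain carbons. Within the data shown here, the only measured step alters a different position of the same chain, replacing the hydroxy further along it, and shows a large loss; it does not test the hydroxy that compound 3 lacks. Among the measured compounds shown here, with no step of the same kind on record, the removed hydroxy is judged on its small size alone, and a step within the scatter, or at most a modest weakening, is expected in this assay, namely a 1.5-fold higher number from compound 1 to compound 3 (0.18 log units; within the scatter). Compound 3 is therefore estimated at 32 nM, in the range 10 nM to 100 nM.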

Compound 3, concentration for 50% growth inhibition: 109 nM
Estimate against measurement, compound 3: 3.4-fold (0.53 log units) below; measured number outside the range, above it.
By their numbers in this assay, from the lowest: compound 1; then compound 3; then compound 2.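

In this assay the loss of the hydroxy on a saturated chain carbon bound to two saturated chain carbons gives a 5.2-fold higher number from compound 1 to compound 3 (0.72 log units; beyond the scatter) in a modest step, so this single oxygen matters in its own right, which the earlier pair, changing only the other hydroxy, could not show. Both hydroxy positions of the (2,3-dihydroxypropyl)sulfanyl chain have now been changed, and each change weakens growth inhibition, while the exchange of 1-hydroxy-2-(piperazin-1-yl)ethyl for 2-hydroxyethyl gives a 3.0-fold lower number from compound 2 to compound 3 (0.48 log units; beyond the scatter) and places the simpler chain ahead of the piperazine one. Nothing available accounts for the size of the hydroxy loss.

From the compounds shown here alone, whether a methoxy group, an amine or fluorine on that carbon could keep the number near that of compound 1 remains open. So does the effect of a longer chain carrying both hydroxy groups.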